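Swapping an Ester Side Chain for a Cyclohexyl Ring

The source may report more compounds than this note shows. Statements on the series, on what has been measured and on what is new or still open speak of the compounds shown alone.

Compound 2 `CCOC(=O)CNc1nc(NC(C)C)nc2ccccc12` and compound 1 `CSCCNc1nc(NC(C)C)nc2ccccc12` share one core and differ only in the group carried on a saturated chain carbon bound to a ring nitrogen. In a physicochemical assay for solubility, at pH 7.4 (on this read-out higher numbers stand for higher solubility and lower numbers for lower solubility), compound 1 gives <= 20000 nM, which is a limit of the assay rather than a number. In this assay compound 2 gives <= 20000 nM, again a limit and not a number. Among the compounds with values here, because of the limit of <= 20000 nM in this assay, at which 2 of the 2 values shown sit, the step that the two limits leave unreadable from compound 1 to compound 2 cannot be read, and so the only measured pair gives no usable size for any step.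

Compound 3 `CC(C)Nc1nc(NC2CCCCC2)c2ccccc2n1` differs from compound 2 by cyclohexyl in place of (ethoxycarbonyl)methyl on a nitrogen on an aromatic ring. Within the data shown here, no measured step covers a change of this kind, so the expectation for compound 3 in this assay rests only on where compound 2 stands, at the limit. The step that the limit leaves unreadable from compound 2 to compound 3 is expected to stay within the scatter, with the result most likely sitting at the limit once more. Compound 3 is therefore estimated at 10000 nM, in a range from 2000 nM to 20000 nM.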

Compound 3, solubility: <= 20000 nM
Compound 3 gave a limit, no number (the forecaster's own chance of this, stated with the estimate: 75%); the middle value is on the limit's open side.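

Neither the step from compound 1 to compound 3 nor the step from compound 2 to compound 3 can be read, because compound 3 also gives a limit rather than a number: the limit of <= 20000 nM in this assay, at which 3 of the 3 values shown sit.

The compounds shown leave open how soluble each one actually is in this assay, and whether cyclohexyl, (ethoxycarbonyl)methyl and 2-(methylsulfanyl)ethyl differ at all.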